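A few compounds are considered here, and "the series" means these few. Any claim that something is new, unique, unknown or untested is made for them only; others in the source may bear on it.

Measured in a functional assay on MCF7 cells (Homo sapiens) for antiproliferative activity, read by CellTiter-Glo, with a stated time of 5 days; on this read-out higher numbers stand for weaker inhibition and lower numbers for stronger inhibition:
- compound 1 `CC1=C(c2ccc(S(C)(=O)=O)cc2)C(c2ccc(OC[C@H](C)N3CC[C@@H](C)C3)cc2)Oc2ccc(O)cc21`: 27 nM
- compound 2 `CC1=C(c2ccc(C#N)cc2)C(c2ccc(OC[C@H](C)N3CC[C@@H](C)C3)cc2)Oc2ccc(O)cc21`: 10 nM
- compound 3 `CC1=C(c2ccc(F)cc2)C(c2ccc(OC[C@H](C)N3CC[C@@H](C)C3)cc2)Oc2ccc(O)cc21`: 0.4 nM

Of these three, compound 3 gives the lowest number, 0.4 nM, and so the strongest inhibition. The next analogue, compound 4 `CC1=C(c2cccc(F)c2)C(c2ccc(OC[C@H](C)N3CC[C@@H](C)C3)cc2)Oc2ccc(O)cc21`, differs from it only on one aromatic ring, with 3-fluorophenyl in place of 4-fluorophenyl on a double-bonded ring carbon.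

All three measured steps swap the group on this same ring. The first is modest, a 2.7-fold lower number from compound 1 to compound 2 (0.43 log units; beyond the scatter). The other two are large, a 25-fold lower number from compound 2 to compound 3 (1.40 log units; beyond the scatter) and a 68-fold lower number from compound 1 to compound 3 (1.83 log units; beyond the scatter). Among the measured compounds shown here, the read-out therefore responds strongly to what this ring carries, but no measured step moves a group to another place on the ring, so the data offer only indirect guidance. The fluorine is kept, which argues against a large loss, while the low starting point of compound 3 at 0.4 nM leaves more room to rise than to fall. A modest step is therefore expected, estimated as a 2.5-fold higher number from compound 3 to compound 4 (0.40 log units; beyond the scatter). For compound 4 the estimated value is 1 nM, with an expected range from 0.3 nM to 3.5 nM.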

Compound 4, half-maximal inhibitory concentration: 1 nM
The estimate for compound 4 equals the measured number at the digits printed; the measured number falls inside the stated range.
By their numbers in this assay, from the lowest: compound 3; then compound 4; then compound 2; then compound 1.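

In this assay, among the compounds shown here, the earlier steps changed only which group this ring carried; 3-fluorophenyl in place of 4-fluorophenyl now shows that the location of the same fluorine also affects the number, with a 2.5-fold higher number from compound 3 to compound 4 (0.40 log units; beyond the scatter). This step is smaller than the two that replace a different group, where 3-fluorophenyl in place of 4-cyanophenyl gives a 10-fold lower number from compound 2 to compound 4 (1.00 log units; beyond the scatter) and 3-fluorophenyl in place of 4-(methylsulfonyl)phenyl gives a 27-fold lower number from compound 1 to compound 4 (1.43 log units; beyond the scatter). No evidence is available on why the location of the fluorine changes the number.

On these data alone, it remains open whether a nitrile or a methylsulfonyl group would respond to the same relocation as fluorine does. As far as these compounds go, how a chloro group, a methoxy group or a plain phenyl ring would compare at this position is also open.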